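An unmeasured chain on the ring nitrogen of compound 3

The source may report more compounds than this note shows. Statements on the series, on what has been measured and on what is new or still open speak of the compounds shown alone.

Three compounds share a core, and the chain on one ring nitrogen changes. In a functional assay on ileum for inhibition of histamine H1 receptor (Cavia porcellus) (a higher number here means a weaker inhibitor, a lower number a stronger inhibitor), compound 1 `CN1CCN(c2nc3ccccc3n2CCO)CC1` gives 410 nM. Compound 2 `CC(C)CCn1c(N2CCN(C)CC2)nc2ccccc21`, with an isopentyl chain in that position, gives 1400 nM in this assay. Compound 3 `CN1CCN(c2nc3ccccc3[nH]2)CC1` carries a plain hydrogen there, and in this assay it gives only a limit, > 3000 nM. Among the values shown, compound 3 sits at the weak end: the step of an at least 7.3-fold higher number from compound 1 to compound 3 (0.86 log units; beyond the scatter) and the step of an at least 2.1-fold higher number from compound 2 to compound 3 (0.33 log units; beyond the scatter) both move toward a higher number, and both exceed the scatter.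

Compound 4 `CCNCCn1c(N2CCN(C)CC2)nc2ccccc21` reverses the direction of those steps: 2-(ethylamino)ethyl in place of hydrogen on an aromatic nitrogen. The 2-(ethylamino)ethyl chain is closer in make-up to the 2-hydroxyethyl chain of compound 1, which carries a hydrogen-bond donor as well, than to the isopentyl chain of compound 2. Compound 4 is therefore expected to return to a lower number, with the expected step of an at least 6.0-fold lower number from compound 3 to compound 4 (0.77 log units; beyond the scatter). The estimated value for compound 4 in this assay is 500 nM, within a range from 150 nM to 2000 nM.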

Compound 4, half-maximal inhibitory concentration: 290 nM
Beside the measured number, compound 4's estimate is 1.7-fold (0.24 log units) above it; low and high end bracket the measured number.
By their numbers in this assay, from the lowest: compounds 4 and 1 (each within the scatter of the next); then compound 2. At a limit, above all of these: compound 3.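

Compound 3 gives only a limit in this assay, not a number: the limit of > 3000 nM in this assay, at which 1 of the 4 values shown sits. Even against that limit, the 2-(ethylamino)ethyl chain on the aromatic nitrogen brings an at least 10-fold lower number from compound 3 to compound 4 (1.01 log units; beyond the scatter), so a second kind of chain now restores the activity that the bare hydrogen lacks. Swapping the hydroxy end of the chain for ethylamino gives a 1.4-fold lower number from compound 1 to compound 4 (0.15 log units; within the scatter), so the two ends cannot be told apart here, whereas ethylamino in place of isopropyl gives a 4.8-fold lower number from compound 2 to compound 4 (0.68 log units; beyond the scatter), so what ends the chain matters and not merely its presence.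

A 2-methoxyethyl or 2-(diethylamino)ethyl chain would show whether the hydrogen on the end group of the chain matters. From the compounds shown here alone, how a longer chain, such as 3-(ethylamino)propyl, would fare at this nitrogen also stays open.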